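Swapping the ring on the amide-type nitrogen

The source may report more compounds than this note shows. Statements on the series, on what has been measured and on what is new or still open speak of the compounds shown alone.

Measured so far:
compound 1 `N=C1S/C(=C\c2ccc(OCc3ccccc3)cc2)C(=O)N1c1cccc([N+](=O)[O-])c1` — 52.9%
compound 2 `N=C1S/C(=C\c2ccc(OCc3ccccc3)cc2)C(=O)N1c1ccc([N+](=O)[O-])cc1` — 17.3%

In an ADME assay on RAW264.7 cells (Mus musculus) for cytotoxicity, read by MTT assay, with a stated time of 48 h, tested at 50 uM (on this read-out lower numbers stand for less inhibition and higher numbers for more inhibition at the one concentration tested (going by the name of the read-out)), compound 2 stands lowest of the two numbers; its nearest neighbour is compound 1, whose value is higher beyond the scatter. Compound 3 `N=C1S/C(=C\c2ccc(OCc3ccccc3)cc2)C(=O)N1c1ncccn1` differs from compound 2 at one place: pyrimidin-2-yl in place of 4-nitrophenyl on an amide-type nitrogen in a ring. Among the measured compounds shown here, the only measured step at this nitrogen, a number 35.6 percentage points lower from compound 1 to compound 2 (beyond the scatter), shows that what sits there moves the number strongly, but it does not say what pyrimidin-2-yl will do. In this assay, for the measured compounds named here, compound 3 is therefore expected to give 30%, with a range from 5% to 60%; the expected step is a number 12.7 percentage points higher from compound 2 to compound 3 (beyond the scatter), in either direction, given the single related step.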

Compound 3, a percentage reported as inhibition, at one concentration (the size of the read-out at that concentration, not a potency): 26.6%
Compound 3: middle estimate off by 3.4 percentage points, on the high side; low and high end bracket the measured number.
By their numbers in this assay, from the lowest: compounds 2 and 3 (each within the scatter of the next); then compound 1.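

In this assay, a nitro-bearing ring is not required for a low number at the amide-type nitrogen: pyrimidin-2-yl in place of 4-nitrophenyl gives a number 9.3 percentage points higher from compound 2 to compound 3 (within the scatter) and so stays level with it. The same replacement for 3-nitrophenyl gives a number 26.3 percentage points lower from compound 1 to compound 3 (beyond the scatter), which leaves compound 1 as the only one of the three standing apart. Nothing available explains these differences.

From the compounds shown here alone, it remains open whether a plain phenyl or a 4-aminophenyl on this nitrogen would stay with compound 2 and compound 3 or move towards compound 1.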